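The source may hold more compounds than are shown below. What is called first, only, known or untested is meant among the compounds shown, and "the series" means these compounds.

In a functional assay on the whole organism with Mus musculus as the target (on this read-out higher numbers stand for an effect only at larger amounts of compound and lower numbers for an effect already at smaller amounts), compound 1 `Cc1c(C)c2c(c(C)c1N)CC(C)(C)O2` gives 7.8 mg/kg and compound 3 `Cc1c(C)c2c(c(C)c1N)CC(C)(Cn1ccnc1)O2` gives 25 mg/kg, the higher of the two exact numbers in this small set. For compound 2 `Cc1c(C)c2c(c(C)c1N)CC(C)(CSCCO)O2` the result is only a limit, > 50 mg/kg. Compound 4 `COC(=O)/C=C\C1(C)Cc2c(C)c(N)c(C)c(C)c2O1` has not yet been measured. It differs from compound 3 in one place, on a saturated ring carbon next to the ring oxygen: 2-(methoxycarbonyl)ethenyl in place of (1H-imidazol-1-yl)methyl on a saturated ring carbon.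

Among the compounds with values here, two measured steps bear on this change. Each replaces a hydrogen on a saturated chain carbon bound to a saturated ring carbon, and both lie beyond the scatter: a 3.2-fold higher number from compound 1 to compound 3 (0.51 log units; beyond the scatter) for 1H-imidazol-1-yl, and an at least 6.4-fold higher number from compound 1 to compound 2 (0.80 log units; beyond the scatter) for (2-hydroxyethyl)sulfanyl. The remaining comparison, an at least 2.0-fold lower number from compound 2 to compound 3 (0.30 log units; that floor lies within the scatter), is a floor within the scatter, so it does not separate those two groups. Within the data shown here, no measured compound carries the 2-(methoxycarbonyl)ethenyl group, so its own effect is unknown. Compound 4 replaces one side chain with another, so with compound 3 at 25 mg/kg as the anchor, no step beyond the scatter is expected in this assay. The expected change is no change at the digits printed from compound 3 to compound 4 (within the scatter). Compound 4 is estimated at 25 mg/kg, with an expected range from 9 mg/kg to 60 mg/kg.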

Compound 4, dose for 50% inhibition: > 100 mg/kg
Compound 4 gave a limit, no number (the forecaster's own chance of this, stated with the estimate: 20%); at least 4.0-fold (0.60 log units) between middle value and limit.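

In this assay, placing 2-(methoxycarbonyl)ethenyl in place of (1H-imidazol-1-yl)methyl on the saturated ring carbon next to the ring oxygen gives an at least 4.0-fold higher number from compound 3 to compound 4 (0.60 log units; beyond the scatter), so the side chain at this position matters even though the two groups match in heavy atoms and hydrogen-bond acceptors as counted. Measured against the plain methyl of compound 1, the same group gives an at least 12-fold higher number from compound 1 to compound 4 (1.10 log units; beyond the scatter), and with it all three side chains shown at this carbon sit on the higher side of compound 1, with no compound going against that. The step between compound 2 and compound 4 cannot be read, and the reading for compound 4 is itself a limit and not a number: the limit of > 100 mg/kg in this assay, at which 1 of the 4 values shown sits.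

The compounds shown do not separate the part played by the ethenyl link from that of the methyl ester, as nothing here pairs the ester with a saturated chain or replaces it with a carboxylic acid or an amide. On these data alone, whether any group at this carbon, such as a primary amine or a longer alkyl chain, would give a lower number than compound 1 at 7.8 mg/kg also stays open.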